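The source may report more compounds than this note shows. Statements on the series, on what has been measured and on what is new or still open speak of the compounds shown alone.

Measured so far:
Compound 1 `Cc1nc2ccc(Cl)cc2c(-c2ccccc2)c1C(=O)OCc1cn(Cc2ccccc2F)nn1`: "not determined" (no result reported)
Compound 2 `COc1cccc(Cn2cc(COC(=O)c3c(C)nc4ccc(Cl)cc4c3-c3ccccc3)nn2)c1`: "not determined" (no result reported)
Compound 3 `Cc1nc2ccc(Cl)cc2c(-c2ccccc2)c1C(=O)OCc1cn(Cc2ccccc2)nn1`: 35000 nM

For the measured compounds named here, in an ADME assay on J774.A1 cells (Mus musculus) for cytotoxicity, read by MTT assay, with a stated time of 48 h (a higher number here means that more compound is tolerated, a lower number that less compound is tolerated), compound 3 gives 35000 nM as the only number, while compound 1 and compound 2 have no reported result. Compound 4 `Cc1ccc(-n2cc(COC(=O)c3c(C)nc4ccc(Cl)cc4c3-c3ccccc3)nn2)cc1F` departs from compound 3 as follows: 3-fluoro-4-methylphenyl in place of benzyl on an aromatic nitrogen. Going by the values given here, the series offers no measured step to go by, so no shift beyond the scatter is expected in this assay and neither direction is favoured. The estimated change is a 1.2-fold lower number from compound 3 to compound 4 (0.07 log units; within the scatter) and is expected to stay within the scatter. The expected value for compound 4 is 30000 nM (estimated range 12000 nM to 80000 nM).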

Compound 4, half-maximal cytotoxic concentration: 34000 nM
Compound 4: the middle estimate sits 1.1-fold (0.05 log units) below what was measured; the range from low to high includes it.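

In this assay, for the compounds shown here, the first readable step at this aromatic nitrogen is a 1.0-fold lower number from compound 3 to compound 4 (0.01 log units; within the scatter) and it concerns 3-fluoro-4-methylphenyl in place of benzyl. Going by these compounds alone, with one step, this says only that these two groups cannot be told apart in the read-out, and it gives no trend for the position. No supporting data bear on why the two compounds read alike.

Still open, from the compounds shown here alone, is how an amine, a carboxylic acid or a longer chain at this aromatic nitrogen would read. Also open, going by these compounds, is whether a phenyl carrying only the fluorine or only the methyl would match compound 4.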